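The source may hold more compounds than are shown below. What is called first, only, known or untested is meant among the compounds shown, and "the series" means these compounds.

Working notes on the series. For the measured compounds named here, the three compounds measured so far share one core and differ only in the group on the saturated chain carbon bound to an oxygen on an aromatic ring. Compound 1 `O=C(Nc1cccnc1)c1ccccc1OCc1ccccc1F` gives 3500 nM in an assay on lysate for inhibition of phosphatidylcholine:ceramide cholinephosphotransferase 2 (Homo sapiens), read by HPLC, with stated times of 30 min and 2 h; a higher number here means a weaker inhibitor, a lower number a stronger inhibitor. Compound 2 `O=C(Nc1cccnc1)c1ccccc1OCc1cccc(F)c1` gives 1600 nM in this assay, a step of a 2.2-fold lower number from compound 1 to compound 2 (0.34 log units; beyond the scatter). Compound 3 `O=C(Nc1cccnc1)c1ccccc1OCc1c(Cl)cccc1Cl` gives 690 nM in this assay and so carries the lowest number of the three; it stands a 2.3-fold lower number from compound 2 to compound 3 (0.37 log units; beyond the scatter) and a 5.1-fold lower number from compound 1 to compound 3 (0.71 log units; beyond the scatter).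

Compound 4 `O=C(Nc1cccnc1)c1ccccc1OCc1cccc(Cl)c1F` is next, with 3-chloro-2-fluorophenyl in place of 2,6-dichlorophenyl on a saturated chain carbon bound to an oxygen on an aromatic ring. Both steps that reach compound 3 bear on this change, since each of them brought the 2,6-dichlorophenyl in; that from compound 1, which holds the 2-fluorophenyl that compound 4 in part keeps, was the larger of the two. Removing the 2,6-dichlorophenyl is therefore expected to give back some of that gain, so a moderate rise in this assay is expected, a 2.2-fold higher number from compound 3 to compound 4 (0.34 log units; beyond the scatter). For compound 4 the expected value in this assay is 1500 nM, within 500 nM to 4500 nM.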

Compound 4, half-maximal inhibitory concentration: 3100 nM
Estimate against measurement, compound 4: 2.1-fold (0.32 log units) below, and the stated range covers the measured number.
By their numbers in this assay, from the lowest: compound 3; then compounds 2, 4 and 1 (each within the scatter of the next, the first and the last beyond it).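

In this assay the 3-chloro-2-fluorophenyl does not hold what the 2,6-dichlorophenyl reached at this position, with a 4.5-fold higher number from compound 3 to compound 4 (0.65 log units; beyond the scatter) for the exchange. Chloro in place of hydrogen on an aromatic carbon leaves no readable difference, with a 1.1-fold lower number from compound 1 to compound 4 (0.05 log units; within the scatter) as its step. The exchange for the 3-fluorophenyl is no more readable, with a 1.9-fold higher number from compound 2 to compound 4 (0.29 log units; within the scatter) as its step, so a chloro group on the ring does not by itself go with a lower number in these compounds.

As far as these compounds go, whether the low number of compound 3 rests on both chloro groups or on one of them stays open, and a 2-chlorophenyl or a 2,6-difluorophenyl at this position would bear on that. From the compounds shown here alone, how a 2,6-dimethylphenyl or a pyridyl ring would compare also stays open. Nothing at hand gives a cause for these steps.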